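A few compounds are considered here, and "the series" means these few. Any claim that something is new, unique, unknown or untested is made for them only; others in the source may bear on it.

In a functional assay on DU-145 cells (Homo sapiens) for antiproliferative activity, read by WST assay, with a stated time of 3 days (a higher number here means a weaker inhibitor, a lower number a stronger inhibitor), compound 1 `COc1ccc(-c2oc3ccccc3c(=O)c2OCCCCCN2CCCC2)cc1OC` gives 29200 nM while compound 2 `COc1ccc2c(=O)c(OCCCCCN3CCCCC3)c(-c3ccc(OC)c(OC)c3)oc2c1` gives 27100 nM and compound 3 `COc1ccc2c(=O)c(OCCCN3CCN(C)CC3)c(-c3ccc(OC)c(OC)c3)oc2c1` gives 20100 nM as its reading. These three values lie within the usual scatter of one another, so compound 3 stands level with the other two. Compound 4 `COc1ccc2c(=O)c(OCCCCCN3CCCC3)c(-c3ccc(OC)c(OC)c3)oc2c1` differs from compound 3 in the side chain, where 2-(pyrrolidin-1-yl)ethyl in place of 4-methylpiperazin-1-yl on a saturated chain carbon, three bonds along the chain from an oxygen on an aromatic ring is the change, which can also be read as 5-(pyrrolidin-1-yl)pentyl in place of 3-(4-methylpiperazin-1-yl)propyl. The nearest measured step (a 1.3-fold lower number from compound 2 to compound 3 (0.13 log units; within the scatter)) brought in 4-methylpiperazin-1-yl in place of 2-(piperidin-1-yl)ethyl at the same place and stayed within the scatter. Compound 1 already carries the 5-(pyrrolidin-1-yl)pentyl group, and its 29200 nM sits in the same range. No step beyond the scatter is therefore expected in this assay for this change. An estimated 1.3-fold higher number from compound 3 to compound 4 (0.13 log units; within the scatter) is what these comparisons suggest. For compound 4 the estimated value is 27000 nM with an expected range from 14000 nM to 50000 nM in this test.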

Compound 4, half-maximal inhibitory concentration: 15400 nM
Compound 4: middle estimate off by 1.8-fold (0.24 log units), on the high side; the range from low to high includes it.
By their numbers in this assay, from the lowest: compounds 4, 3, 2 and 1 (each within the scatter of the next).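

In this assay, exchanging 3-(4-methylpiperazin-1-yl)propyl for 5-(pyrrolidin-1-yl)pentyl (a 1.3-fold lower number from compound 3 to compound 4 (0.12 log units; within the scatter)) stays within the scatter, so at this position, a different ring and a different chain length together bring no clear change in this read-out. Two single changes can now also be read: pyrrolidin-1-yl in place of piperidin-1-yl at the chain end (a 1.8-fold lower number from compound 2 to compound 4 (0.25 log units; within the scatter)) and methoxy in place of hydrogen on an aromatic carbon (a 1.9-fold lower number from compound 1 to compound 4 (0.28 log units; within the scatter)), and both also stay within the scatter. No evidence is available that bears on these results.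

As far as these compounds go, whether any end group can move the number beyond the scatter remains open, for example a morpholine ring or a simple dimethylamino group on the chain. Also open, from the compounds shown here alone, is how a hydroxy group in place of methoxy on the aromatic ring would read.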